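From compound 2 to compound 4: fluoro for methyl

The source may hold more compounds than are shown below. What is called first, only, known or untested is meant among the compounds shown, and "the series" means these compounds.

Measured in a functional assay on HCT-116 cells (Homo sapiens) for antiproliferative activity, read by MTT assay, with a stated time of 72 h; on this read-out lower numbers stand for stronger inhibition and higher numbers for weaker inhibition:
compound 1 `C=C1CN/C(=N/c2ccccc2)S1`: > 100000 nM (a limit)
compound 2 `COc1ccc(/C=C2/CN(C)/C(=N/c3ccc(C)cc3)S2)cc1`: 11100 nM
compound 3 `S=C(Nc1ccccc1)N1C/C(=C/c2ccccc2)S/C1=N\c1ccccc1`: > 100000 nM (a limit)

Going by the values given here, compound 2 carries the only number in the set, 11100 nM. Compound 1 and compound 3 give no number, only (the limit of > 100000 nM in this assay, at which 2 of the 3 values shown sit).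

Compound 4 `COc1ccc(/C=C2/CN(C)/C(=N/c3ccc(F)cc3)S2)cc1` departs from compound 2 in one place, fluoro in place of methyl on an aromatic carbon, para to a large group. Among the compounds with values here, no measured pair isolates such a change. In this assay, the expected outcome is no shift beyond the scatter and no favoured direction, an estimated step of a 1.1-fold higher number from compound 2 to compound 4 (0.03 log units; within the scatter). This expectation is anchored on compound 2 at 11100 nM. The estimate for compound 4 is 12000 nM, with an expected range of 4500 nM to 35000 nM.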

Compound 4, half-maximal inhibitory concentration: 10000 nM
For compound 4 the middle estimate is 1.2-fold (0.08 log units) above the measured one, within the range that was stated.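

In this assay, going by these compounds alone, the change from 4-methylphenyl to 4-fluorophenyl provides the first comparison that differs in one place, and it gives a 1.1-fold lower number from compound 2 to compound 4 (0.05 log units; within the scatter). At this position on the aromatic ring, fluoro and methyl therefore cannot be told apart on this read-out. Only this pair can be compared by number, as the other compounds give a limit only: the limit of > 100000 nM in this assay, at which 2 of the 4 values shown sit.

Going by these compounds, whether an amine, a nitrile or a carboxylic acid in this same position would move the number beyond the scatter remains open.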